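Adding a second bromo to compound 3

The source may hold more compounds than are shown below. What is called first, only, known or untested is meant among the compounds shown, and "the series" means these compounds.

compound 1 `COC(=O)CC1CNC(=O)c2cc(Br)c(Br)n21` gives 82000 nM
compound 2 `CCOC(=O)CC1CNC(=O)c2cc(Br)c(Br)n21` gives 41000 nM
compound 3 `COC(=O)Cc1c[nH]c(=O)c2ccc(Br)n12` gives 165000 nM

In a functional assay on A549 cells (Homo sapiens) for cytotoxicity, read by CCK-8 assay, with a stated time of 72 h (on this read-out higher numbers stand for weaker inhibition and lower numbers for stronger inhibition), compound 3 gives 165000 nM, within the scatter of compound 1 and beyond the scatter from the lower number of compound 2. Compound 4 `COC(=O)Cc1c[nH]c(=O)c2cc(Br)c(Br)n12` differs from compound 3 in one place, bromo in place of hydrogen on an aromatic carbon. Among the measured compounds shown here, the only measured step, a 2.0-fold lower number from compound 1 to compound 2 (0.30 log units; within the scatter), lies on the ester chain and does not size this change. Compound 1 also carries this bromo and gives 82000 nM, but its core differs, so it is only a loose guide. A modest move to a lower number is expected, a 1.9-fold lower number from compound 3 to compound 4 (0.29 log units; within the scatter), near the edge of the scatter. For compound 4 the estimated value is 85000 nM, with an expected range of 35000 nM to 170000 nM.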

Compound 4, half-maximal inhibitory concentration: > 200000 nM
Compound 4: a limit, no number (the forecaster's own chance of this, stated with the estimate: 5%); at least 2.3-fold (0.37 log units) between middle value and limit.
By their numbers in this assay, from the lowest: compounds 2, 1 and 3 (each within the scatter of the next, the first and the last beyond it). At a limit, above all of these: compound 4.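

In this assay compound 4 gives > 200000 nM, which is a limit of the assay and not a number. Bromo in place of hydrogen on this aromatic carbon therefore brings no sign of stronger inhibition on the shared core, with an at least 1.2-fold higher number from compound 3 to compound 4 (0.08 log units; that floor lies within the scatter). Only this floor can be read, so the change may do nothing or may weaken inhibition further.

Going by these compounds, how far the true value of compound 4 lies past the limit stays open. So does how a chloro or methyl group on this same aromatic carbon would read.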